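This account rests on a few compounds, and the source may have more. Where it says the series, first, only, none or still open, it means among the compounds named here.

Working notes on the series. In a functional assay on PANC-1 cells (Homo sapiens) for antiproliferative activity, read by MTT assay, with a stated time of 48 h (a lower number here means a stronger inhibitor, a higher number a weaker inhibitor), compound 1 (`COc1ccc(-c2c(Nc3cc(OC)c(OC)c(OC)c3)c3ccccc3oc2=O)cc1`) gives 77600 nM and compound 3 (`COc1ccc(-c2c(Nc3cc(OC)c(OC)c(OC)c3)c3ccc(O)cc3oc2=O)cc1`) gives 63900 nM. Compound 2 (`COc1ccc(-c2c(Nc3cc(OC)c(OC)c(OC)c3)c3ccc(OC)cc3oc2=O)cc1`) has no number to stand on, since compound 2 is recorded as "not determined" (no result reported). The step from it to compound 4 (`COc1ccc2c(Nc3cc(OC)c(OC)c(OC)c3)c(C(=O)C(F)(F)F)c(=O)oc2c1`) therefore starts from no measured value.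

The change is (trifluoromethyl)carbonyl in place of 4-methoxyphenyl on an aromatic carbon. Going by the values given here, only one measured step exists, a 1.2-fold lower number from compound 1 to compound 3 (0.08 log units; within the scatter). It is hydroxy in place of hydrogen on an aromatic carbon, and it leaves the 4-methoxyphenyl group in place. It shows that this one edit to the shared core stays within the scatter, but it says nothing about replacing the 4-methoxyphenyl group.

Among the compounds with values here, no measured step tests the present swap, so its size cannot be derived from the data. With compound 1 and compound 3 as the only anchors, a moderate move to a lower number in this assay is expected, though this is held loosely and the range is kept wide. Compound 4 is estimated at 30000 nM, with an expected range of 6000 nM to 120000 nM.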

Compound 4, half-maximal inhibitory concentration: 24100 nM
For compound 4 the middle estimate is 1.2-fold (0.10 log units) above the measured one; the range from low to high includes it.
By their numbers in this assay, from the lowest: compound 4; then compounds 3 and 1 (each within the scatter of the next).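

No new step can be read: compound 2 has no single number in this assay, so the change from compound 2 to compound 4 has no measurable size. The compounds shown leave open how (trifluoromethyl)carbonyl compares with 4-methoxyphenyl on an otherwise identical core. No available evidence bears on the result for compound 4.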